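Pyrazole carboxamide series: aryl substituent restored on N-methyl amide

The source may hold more compounds than are shown below. What is called first, only, known or untested is meant among the compounds shown, and "the series" means these compounds.

Measured so far:
compound 1 `COc1cccc(Cn2cc(C(=O)Nc3ccc(C)c(S(=O)(=O)N4CCOCC4)c3)c(-c3cccc(OC)c3)n2)c1` — 42.8 nM
compound 2 `COc1cccc(Cn2cc(C(=O)N(C)c3ccc(C)c(S(=O)(=O)N4CCOCC4)c3)c(C(C)C)n2)c1` — 5330 nM

In an assay on isolated protein for antagonist activity at Bile acid receptor (Homo sapiens), read by TR-FRET, with a stated time of 20 min (on this read-out lower numbers stand for stronger inhibition and higher numbers for weaker inhibition), compound 1 gives 42.8 nM, while compound 2 gives 5330 nM. Of the two numbers, compound 2 stands at the higher, weaker end, and the gap to compound 1 lies well beyond the scatter. The two structures differ in more than one place, so the gap cannot be assigned to a single change.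

Compound 3 `COc1cccc(Cn2cc(C(=O)N(C)c3ccc(C)c(S(=O)(=O)N4CCOCC4)c3)c(-c3cccc(OC)c3)n2)c1` is not yet measured. It differs from compound 2 in one place: 3-methoxyphenyl in place of isopropyl on an aromatic carbon. Compound 3 carries the aryl group of compound 1 together with the methylated amide of compound 2.

Since compound 1 gives 42.8 nM, the step from compound 2 to compound 3 is expected to lower the number by a clear margin, an 18-fold lower number from compound 2 to compound 3 (1.25 log units; beyond the scatter). Compound 3 is estimated at 300 nM, within 60 nM to 1500 nM.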

Compound 3, half-maximal inhibitory concentration: 3810 nM
Estimate against measurement, compound 3: 13-fold (1.10 log units) below; the whole stated range lies below it.
By their numbers in this assay, from the lowest: compound 1; then compounds 3 and 2 (each within the scatter of the next).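

With the amide methylated, 3-methoxyphenyl in place of isopropyl on the aromatic carbon gives in this assay only a 1.4-fold lower number from compound 2 to compound 3 (0.15 log units; within the scatter) and so does not bring the number back towards that of compound 1. Among the compounds shown here, the large change instead follows methyl in place of hydrogen on the amide-type nitrogen, with an 89-fold higher number from compound 1 to compound 3 (1.95 log units; beyond the scatter) as a single-place step that the two-place gap between the earlier compounds could not isolate. No measurement at hand bears on the reason for this loss.

Open, from the compounds shown here alone, is whether the isopropyl group, paired with the amide hydrogen, would read close to compound 1, which would show whether the aryl group matters once that hydrogen is present. Also open, going by these compounds, is how an ethyl group on the amide nitrogen, or an amine or a carboxylic acid on the aryl ring, would read in this assay.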